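Hydrogen for Chlorine on Two Related Cores

The source may report more compounds than this note shows. Statements on the series, on what has been measured and on what is new or still open speak of the compounds shown alone.

The study concerns four compounds tested in a functional assay on EC9706 cells (Homo sapiens) for cytotoxicity, read by MTT assay, with a stated time of 72 h; a lower number here means a stronger inhibitor, a higher number a weaker inhibitor. Compound 1 `O=C(CCl)Nc1ccc(C(=O)/C=C/c2ccc(Cl)cc2)cc1` gives 8340 nM in this assay. Compound 2 `O=C(CCl)Nc1ccc(C(=O)/C=C/c2ccccc2)cc1` differs from compound 1 in that (hydrogen in place of chloro on an aromatic carbon); in this assay compound 2 gives 6370 nM, and the step is a 1.3-fold lower number from compound 1 to compound 2 (0.12 log units; within the scatter). Compound 3 `O=C(CSC(=S)N[C@H]1CCOC1=O)Nc1ccc(C(=O)/C=C/c2ccc(Cl)cc2)cc1` is built on a different core: relative to compound 1 the difference is a group of 10 heavy atoms (5 carbon, 1 nitrogen, 2 oxygen, 2 sulfur; one five-membered non-aromatic ring with 1 hetero atom) in place of one chlorine atom, on a saturated chain carbon bound to a carbonyl carbon. In this assay compound 3 gives 38900 nM, the highest number of the three measured compounds, and the step is a 4.7-fold higher number from compound 1 to compound 3 (0.67 log units; beyond the scatter).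

Compound 4 `O=C(CSC(=S)N[C@H]1CCOC1=O)Nc1ccc(C(=O)/C=C/c2ccccc2)cc1` has not yet been measured. It differs from compound 3 in that (hydrogen in place of chloro on an aromatic carbon). This is the same change as that from compound 1 to compound 2, the surroundings of the place being described in the same words in both cases, and it occurs twice among the four compounds. Because the first occurrence of the change gave a 1.3-fold lower number from compound 1 to compound 2 (0.12 log units; within the scatter), a step that sits within the usual scatter, compound 4 is expected to lie close to compound 3, with an estimated step of a 1.3-fold lower number from compound 3 to compound 4 (0.10 log units; within the scatter). Nothing in the data suggests that the core of compound 3 should respond to this change differently from the core of compound 1. Compound 4 is therefore estimated at 31000 nM in this assay, with a likely range from 15000 nM to 65000 nM.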

Compound 4, half-maximal inhibitory concentration: 44900 nM
For compound 4 the middle estimate is 1.4-fold (0.16 log units) below the measured one; measured number inside the range.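

In this assay, the change from 4-chlorophenyl to phenyl on the second core gave a 1.2-fold higher number from compound 3 to compound 4 (0.06 log units; within the scatter), and set beside its first occurrence it carries across the two cores without a difference that can be told from scatter: the same change on two cores in this assay, a 1.3-fold lower number (0.12 log units; within the scatter) from compound 1 to compound 2 and a 1.2-fold higher number (0.06 log units; within the scatter) from compound 3 to compound 4, 1.5-fold (0.18 log units) apart, within the scatter of two such steps

The larger replacement on the saturated chain carbon, read on the pair without chloro, gave a 7.0-fold higher number from compound 2 to compound 4 (0.85 log units; beyond the scatter), and it too agrees with its earlier reading on the chloro pair: the same change on two cores in this assay, a 4.7-fold higher number (0.67 log units; beyond the scatter) from compound 1 to compound 3 and a 7.0-fold higher number (0.85 log units; beyond the scatter) from compound 2 to compound 4, 1.5-fold (0.18 log units) apart, within the scatter of two such steps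

This shows that in these four compounds the two changes can be read independently of each other, but it does not show that hydrogen in place of chloro has any effect of its own on either core, nor that the agreement would hold on a core outside this set or in another assay.

From the compounds shown here alone, whether a bromo or methoxy group on the same aromatic carbon would also leave the number within the scatter on both cores remains open. Also open, going by these compounds, is whether an amine or a longer chain on the saturated chain carbon would give a step of the size seen with the large group.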